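The compounds below may be only part of what the source reports. "The series", "measured", "known", "first", "only" and "open" are said of these compounds alone.

Among the measured compounds shown here, compound 1 `O=S(=O)(NCCCCNCc1ccc(Br)cc1)c1cc(C(F)(F)F)cc(C(F)(F)F)c1` gives 2200 nM in a functional assay on BE(2)-C cells (Homo sapiens) for inhibition, read by MTT assay, with a stated time of 72 h (a lower number here means a stronger inhibitor of growth, a higher number a weaker inhibitor of growth), the lowest of the two numbers so far; compound 2 `O=S(=O)(NCCCNCc1ccc(Cl)cc1)c1cc(C(F)(F)F)cc(C(F)(F)F)c1` gives 2900 nM in this assay. For the measured compounds named here, the only measured step, a 1.3-fold higher number from compound 1 to compound 2 (0.12 log units; within the scatter), combines a shorter chain with chlorine in place of bromine. Compound 3 `O=S(=O)(NCCCNCc1ccc(Br)cc1)c1cc(C(F)(F)F)cc(C(F)(F)F)c1` keeps bromine and alters the chain alone: (4-bromobenzyl)amino in place of ((4-bromobenzyl)amino)methyl on a saturated chain carbon, three bonds along the chain from a sulfonamide nitrogen. Because a 1.3-fold higher number from compound 1 to compound 2 (0.12 log units; within the scatter) lay within the scatter, the expected step is a 1.2-fold higher number from compound 1 to compound 3 (0.07 log units; within the scatter), no more than the scatter. Compound 3 is therefore estimated at 2600 nM, within the range 1300 nM to 5200 nM.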

Compound 3, concentration for 50% growth inhibition: 2700 nM
Estimate against measurement, compound 3: 1.0-fold (0.02 log units) below; the measured number falls inside the stated range.
By their numbers in this assay, from the lowest: compounds 1, 3 and 2 (each within the scatter of the next).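

Taken apart, the two changes each stay small in this assay: a 1.2-fold higher number from compound 1 to compound 3 (0.09 log units; within the scatter) for the chain change alone, and a 1.1-fold lower number from compound 2 to compound 3 (0.03 log units; within the scatter) for bromo in place of chloro on an aromatic carbon. Neither change on its own moves the number beyond the scatter, so the small combined step seen earlier does not conceal two large opposing steps among compounds 1, 2 and 3. No measured evidence bears on these results.

Still open, on these data alone, is whether a chain longer than that of compound 1 behaves the same way. Also open, as far as these compounds go, is whether a methoxy group or a nitrile in place of the halogen, or an amide in place of the secondary amine, keeps the number at this level.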